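A few compounds are considered here, and "the series" means these few. Any claim that something is new, unique, unknown or untested is made for them only; others in the source may bear on it.

Going by the values given here, compound 2 `CCCc1nnc2sc(-c3c[nH]nc3-c3ccc(Cl)cc3)nn12` stands highest of the two compounds so far measured in a functional assay on the whole organism (strain Wistar) for inhibition, with Rattus norvegicus as the target, read by paw edema, with stated times of 30 min and 2.5 h, at a dose of 20 mg/kg by the intraperitoneal route (a higher number here means more inhibition at the dose given (going by the name of the read-out), a lower number less inhibition), where compound 2 gives 64.7%, while compound 1 `CCCc1nnc2sc(-c3c[nH]nc3-c3ccc(OC)cc3)nn12` gives 13.5%. Among the compounds with values here, the single step seen so far, a number 51.2 percentage points higher from compound 1 to compound 2 (beyond the scatter), exchanges one group for another and bears only loosely on the next change. Compound 3 `CCCc1nnc2sc(-c3c[nH]nc3-c3ccc(Cl)cc3Cl)nn12` differs from compound 2 by chloro in place of hydrogen on an aromatic carbon. Within the data shown here, no measured step adds a chloro where a hydrogen stood, so the direction is open, and the step is expected to stay within the scatter, a number 1.7 percentage points lower from compound 2 to compound 3 (within the scatter). Compound 3 is therefore estimated at 63%, within a range from 40% to 82%.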

Compound 3, a percentage reported as inhibition, in the whole organism at one dose (the size of the read-out at that dose, not a potency): 23.5%
Compound 3: middle estimate off by 39.5 percentage points, on the high side, outside the stated range (below it).
By their numbers in this assay, from the lowest: compounds 1 and 3 (each within the scatter of the next); then compound 2.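

Going from 4-chlorophenyl to 2,4-dichlorophenyl in this assay gives a number 41.2 percentage points lower from compound 2 to compound 3 (beyond the scatter), so a chloro placed ortho to a large group removes most of the inhibition seen with the single chloro. The step of a number 10 percentage points higher from compound 1 to compound 3 (within the scatter) puts the dichloro compound level with the methoxy compound, so the gain of the first exchange does not survive this addition. No evidence at hand bears on this drop. The compounds shown leave open whether a fluoro or a methyl at this same place would cost as much, and whether the loss depends on the chloro already on the ring.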